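The compounds below may be only part of what the source reports. "The series", "measured", "known", "first", "only" and "open" are said of these compounds alone.

Three compounds sharing one core have been measured in a functional assay on HeLa cells (Homo sapiens) for cytotoxicity, read by MTT assay, with a stated time of 48 h; a lower number here means a stronger inhibitor, a higher number a weaker inhibitor:

compound 1, `CCOC(=O)c1c(-c2cc3ccccc3oc2=O)nn(-c2cccc(Cl)c2)c1C(=O)OCC`, 22000 nM
compound 2, `CCOC(=O)c1c(-c2cc3ccccc3oc2=O)nn(-c2cccc(F)c2)c1C(=O)OCC`, 68000 nM
compound 3, `CCOC(=O)c1c(-c2cc3cc(OC)ccc3oc2=O)nn(-c2cccc(Cl)c2)c1C(=O)OCC`, 160000 nM

Among these three numbers compound 1 stands lowest, meaning it is the strongest inhibitor of the group. The nearest of the others lies a 3.1-fold higher number from compound 1 to compound 2 (0.49 log units; beyond the scatter), and the furthest lies a 7.3-fold higher number from compound 1 to compound 3 (0.86 log units; beyond the scatter); both steps are beyond the scatter.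

Compound 4, `CCOC(=O)c1c(-c2cc3ccc(OC)cc3oc2=O)nn(-c2cccc(Cl)c2)c1C(=O)OCC`, has not yet been measured. It differs from compound 1 in one place: methoxy in place of hydrogen on an aromatic carbon. For the measured compounds named here, of the two measured steps, only one bears on this change: a 7.3-fold higher number from compound 1 to compound 3 (0.86 log units; beyond the scatter), where a methoxy also replaced a hydrogen on the same fused ring, though at a different place on that ring. That step was modest and beyond the scatter, in the weakening direction. The other step, a 3.1-fold higher number from compound 1 to compound 2 (0.49 log units; beyond the scatter), concerns a different ring and offers no guide here. Going by the values given here, since the earlier methoxy step is the only precedent, and it sits at another place, the number for compound 4 is expected to rise by a modest amount, estimated as a 4.1-fold higher number from compound 1 to compound 4 (0.61 log units; beyond the scatter). For compound 4 the estimate in this assay is 90000 nM, with an expected range from 30000 nM to 300000 nM.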

Compound 4, half-maximal inhibitory concentration: 205000 nM
For compound 4 the middle estimate is 2.3-fold (0.36 log units) below the measured one, within the range that was stated.
By their numbers in this assay, from the lowest: compound 1; then compound 2; then compounds 3 and 4 (each within the scatter of the next).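

In this assay, methoxy in place of hydrogen on an aromatic carbon of the fused system, meta to a fused ring and para to a fused ring, gives a clear weakening (a 9.3-fold higher number from compound 1 to compound 4 (0.97 log units; beyond the scatter)). The loss seen with compound 3 is therefore not tied to a single place on that ring: two different places for the methoxy both give a higher number than hydrogen does in compound 1. Compound 3 at (160000 nM) and compound 4 at (205000 nM) lie within the scatter of each other, so these data cannot separate the two places, and nothing shown explains the loss in either compound.

Still open, as far as these compounds go, is what a hydroxyl, an amine or a longer chain such as ethoxy would do at this place in place of the methoxy. Also open, from the compounds shown here alone, is whether methoxy here would raise the number to a similar extent on compound 2, which carries fluoro rather than chloro on its other aromatic ring.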